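The source may hold more compounds than are shown below. What is called first, only, known or untested is meant among the compounds shown, and "the series" means these compounds.

Of the compounds shown here, three built on one shared core have been measured in a functional assay on CCRF-CEM cells (Homo sapiens) for cytotoxicity, in the absence of a further agent (on this read-out higher numbers stand for weaker inhibition and lower numbers for stronger inhibition), so far. Compound 1 `CC(C)(C)OC(=O)CCC(Nc1ccc(CN(CCCc2c(N)nc(N)nc2O)c2cc(F)c([N+](=O)[O-])cc2[N+](=O)[O-])cc1)C(=O)OC(C)(C)C` gives 2600 nM and compound 2 `CC(C)(C)OC(=O)CCC(Nc1ccc(CN(CCCc2c(N)nc(N)nc2O)c2cc(F)cc(F)c2[N+](=O)[O-])cc1)C(=O)OC(C)(C)C` gives 17000 nM in this test. Compound 3 `CC(C)(C)OC(=O)CCC(Nc1ccc(CN(CCCc2c(N)nc(N)nc2O)c2ccc([N+](=O)[O-])c(F)c2F)cc1)C(=O)OC(C)(C)C` gives 36000 nM as the highest of the three numbers, and so the weakest inhibition. Compound 4 `CC(C)(C)OC(=O)CCC(Nc1ccc(CN(CCCc2c(N)nc(N)nc2O)c2cc(F)c(F)cc2[N+](=O)[O-])cc1)C(=O)OC(C)(C)C` has not yet been measured. It has 4,5-difluoro-2-nitrophenyl in place of 2,3-difluoro-4-nitrophenyl on an amine nitrogen, and the two compounds have the same atoms joined differently: 4,5-difluoro-2-nitrophenyl in place of 2,3-difluoro-4-nitrophenyl on an amine nitrogen. Within the data shown here, the only measured step that bears on this is a 2.1-fold higher number from compound 2 to compound 3 (0.33 log units; beyond the scatter), a modest change that lies beyond the scatter. It exchanged 3,5-difluoro-2-nitrophenyl for the group that compound 4 now gives up. Among the measured compounds shown here, since compound 4 returns to a 2-nitrophenyl group, that step is expected to reverse roughly, though no measured compound carries the entering group. An estimated 2.6-fold lower number from compound 3 to compound 4 (0.41 log units; beyond the scatter) is therefore expected in this assay as a modest move. Compound 4 is expected at about 14000 nM with an estimated range of 4500 nM to 36000 nM on this evidence.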

Compound 4, half-maximal inhibitory concentration: 3400 nM
The estimate for compound 4 lay 4.1-fold (0.61 log units) above the measured number, and the stated range ends above it.
By their numbers in this assay, from the lowest: compounds 1 and 4 (each within the scatter of the next); then compound 2; then compound 3.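

Rearranging the same atoms on the amine nitrogen proved decisive in this assay, with an 11-fold lower number from compound 3 to compound 4 (1.02 log units; beyond the scatter), a large step that the earlier compounds did not reveal. The 2-nitrophenyl pattern alone does not fix the number, as 4,5-difluoro-2-nitrophenyl and 3,5-difluoro-2-nitrophenyl differ by a 5.0-fold lower number from compound 2 to compound 4 (0.70 log units; beyond the scatter). On the aromatic carbon where compound 1 and compound 4 differ, fluoro in place of nitro gives a 1.3-fold higher number from compound 1 to compound 4 (0.12 log units; within the scatter), so this assay does not separate the two groups there.

Nothing available explains why the arrangement of these groups matters. The compounds shown leave open whether a chloro group in place of the fluoro groups, or a carboxylic acid in place of the tert-butyl esters, would preserve the number seen for compound 4.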